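The compounds below may be only part of what the source reports. "The series", "measured", "known", "first", "only" and "open" are said of these compounds alone.

Three compounds have been measured so far in a functional assay on the whole organism for inhibition, with Rattus norvegicus as the target; on this read-out lower numbers stand for an effect already at smaller amounts and higher numbers for an effect only at larger amounts of compound:

Compound 1, `CC1CC/C(=N\Nc2ccc(Cl)cc2)c2ncc(C(=O)O)c(=O)n21`, gives 0.5 umol/kg.
Compound 2, `Cc1ccc(N/N=C2\CCC(C)n3c2ncc(C(=O)O)c3=O)cc1`, gives 1.3 umol/kg.
Compound 3, `CC1CC/C(=N\Nc2ccc([N+](=O)[O-])cc2)c2ncc(C(=O)O)c(=O)n21`, gives 0.8 umol/kg.

Among these three numbers compound 3 holds the second highest place. The step of a 1.6-fold higher number from compound 1 to compound 3 (0.20 log units; within the scatter) is within the scatter, and so is a 1.6-fold lower number from compound 2 to compound 3 (0.21 log units; within the scatter); the values of compound 1 and compound 2 are therefore not distinguishable from that of compound 3. Among the compounds with values here, the only step beyond the scatter is a 2.6-fold higher number from compound 1 to compound 2 (0.41 log units; beyond the scatter), and even that one is modest.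

Compound 4, `CC(=O)c1ccc(N/N=C2\CCC(C)n3c2ncc(C(=O)O)c3=O)cc1`, has not yet been measured. It differs from compound 3 by acetyl in place of nitro on an aromatic carbon. Within the data shown here, no measured step involves acetyl, so the steps that bear on it are those in which the group at this same place was exchanged: a 1.6-fold higher number from compound 1 to compound 3 (0.20 log units; within the scatter) and a 1.6-fold lower number from compound 2 to compound 3 (0.21 log units; within the scatter), both within the scatter, and a 2.6-fold higher number from compound 1 to compound 2 (0.41 log units; beyond the scatter). On this evidence exchanges at this place have moved the number little. The step of a 1.1-fold higher number from compound 3 to compound 4 (0.05 log units; within the scatter) is therefore expected to stay within the scatter. The estimate for compound 4 is 0.9 umol/kg, with a range from 0.4 umol/kg to 2 umol/kg.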

Compound 4, dose for 50% inhibition: 9.5 umol/kg
Estimate against measurement, compound 4: 11-fold (1.02 log units) below; measured number above the stated range.
By their numbers in this assay, from the lowest: compounds 1, 3 and 2 (each within the scatter of the next, the first and the last beyond it); then compound 4.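

In this assay, within the data shown here, the place on the six-membered aromatic ring of carbon only, para to a large group, proves much less forgiving than the chloro, methyl and nitro compounds had suggested: the change to acetyl gives a 12-fold higher number from compound 3 to compound 4 (1.07 log units; beyond the scatter) and a 7.3-fold higher number from compound 2 to compound 4 (0.86 log units; beyond the scatter) and a 19-fold higher number from compound 1 to compound 4 (1.28 log units; beyond the scatter) and each of these exceeds every step among the earlier compounds. Nitro and acetyl match in heavy-atom count and in having one double bond outside aromatic rings, yet these shared counts do not keep the numbers of compound 3 and compound 4 together. Nothing available accounts for this jump.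

As far as these compounds go, whether the jump is particular to acetyl remains open, since a propionyl group, an amine or a carboxylic acid at this place could fall on either side. Whether it would recur on a different core is also unsettled.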